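Removing the phenyl ring from the benzyl urea of compound 3

The source may hold more compounds than are shown below. What is called first, only, known or untested is meant among the compounds shown, and "the series" means these compounds.

The compounds here share one core and differ only in the groups hanging from it. Compound 1 `Cc1cn([C@@H]2O[C@H](CO[Si](C)(C)C(C)(C)C)[C@@]3(OS(=O)(=O)C=C3NC(=O)NC(=O)c3ccccc3)[C@H]2O[Si](C)(C)C(C)(C)C)c(=O)n(C)c1=O` carries a benzoyl urea and two silyl-protected hydroxyl groups. In an ADME assay on HEL cells (Homo sapiens) for cytotoxicity, with a stated time of 3 days (a higher number here means that more compound is tolerated, a lower number that less compound is tolerated), compound 1 gives only a limit, > 200000 nM. Compound 2 `Cc1cn([C@@H]2O[C@H](CO)[C@@]3(OS(=O)(=O)C=C3NC(=O)NC(=O)c3ccccc3)[C@H]2O[Si](C)(C)C(C)(C)C)c(=O)n(C)c1=O` loses one silyl group and gives 16000 nM. Compound 3 `Cc1cn([C@@H]2O[C@H](CO[Si](C)(C)C(C)(C)C)[C@@]3(OS(=O)(=O)C=C3NC(=O)NCc3ccccc3)[C@H]2O[Si](C)(C)C(C)(C)C)c(=O)n(C)c1=O` keeps both silyl groups but carries a benzyl instead of the benzoyl, and gives 4100 nM, the lower of the two numbers shown.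

Both measured steps start from compound 1: an at least 12-fold lower number from compound 1 to compound 2 (1.09 log units; beyond the scatter) and an at least 48-fold lower number from compound 1 to compound 3 (1.68 log units; beyond the scatter); neither is small, and both lean the same way. Because compound 1 sits at the limit of > 200000 nM in this assay, at which 1 of the 3 values shown sits, their true sizes could be larger still.

Compound 4 `CCNC(=O)NC1=CS(=O)(=O)O[C@@]12[C@@H](CO[Si](C)(C)C(C)(C)C)O[C@@H](n1cc(C)c(=O)n(C)c1=O)[C@@H]2O[Si](C)(C)C(C)(C)C` takes the change (methyl in place of phenyl on a saturated chain carbon bound to an amide-type nitrogen), so the benzyl becomes an ethyl. For the measured compounds named here, no measured step removes a phenyl in this way, so the expectation leans on the nearby change from benzoyl to benzyl only loosely. For compound 4 a small to moderate step is expected, a 2.2-fold higher number from compound 3 to compound 4 (0.34 log units; beyond the scatter), towards a higher number. Compound 4 is therefore estimated at 9000 nM, likely between 2500 nM and 40000 nM.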

Compound 4, half-maximal cytotoxic concentration: 10000 nM
Estimate against measurement, compound 4: 1.1-fold (0.05 log units) below; measured number inside the range.
By their numbers in this assay, from the lowest: compound 3; then compounds 4 and 2 (each within the scatter of the next). At a limit, above all of these: compound 1.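

In this assay, for the compounds shown here, taking the phenyl ring off the benzyl urea moves the number only modestly, with a 2.4-fold higher number from compound 3 to compound 4 (0.39 log units; beyond the scatter), and this is the first view of what that ring contributes on its own at this position. The ethyl urea still lies far from the benzoyl urea, with an at least 20-fold lower number from compound 1 to compound 4 (1.30 log units; beyond the scatter), so removing the phenyl ring from the benzyl group recovers only a part of the distance to the benzoyl compound, and a small chain without any ring does not restore the tolerance recorded there. The true size of that large step may be greater still, since compound 1 gives only a limit: the limit of > 200000 nM in this assay, at which 1 of the 4 values shown sits.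

On these data alone, it remains open whether a longer chain such as propyl, or an amine or a carboxylic acid at the end of the chain, would move the number further in the same direction or back towards compound 3. Also open, as far as these compounds go, is whether ethyl in place of benzoyl would act in the same way with one silyl group gone, as in compound 2.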